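Alkyne side-chain series: oxetane in place of methoxymethyl

The compounds below may be only part of what the source reports. "The series", "measured", "known", "first", "only" and "open" are said of these compounds alone.

Compound 3 `COCCC#Cc1c(Cl)c2c(Cl)cc(C(N)=O)nc2n1[C@H]1CCCNC1` gives 39 nM in a functional assay on KG-1 cells (Homo sapiens) for antiproliferative activity (on this read-out higher numbers stand for an effect only at larger amounts of compound and lower numbers for an effect already at smaller amounts), the lowest of the two single numbers at hand; compound 2 `CC(O)C#Cc1c(Cl)c2c(Cl)cc(C(N)=O)nc2n1[C@H]1CCCNC1` gives 147 nM, and compound 1 `NC(=O)c1cc(Cl)c2c(Cl)c(C#CC3CCCO3)n([C@H]3CCCNC3)c2n1` has repeat entries of 223 nM; 91 nM (2 entries). Among the compounds with values here, the only single-point step measured is a 3.8-fold lower number from compound 2 to compound 3 (0.58 log units; beyond the scatter), which exchanges one oxygen-bearing chain for another. Compound 4 `CC1(CC#Cc2c(Cl)c3c(Cl)cc(C(N)=O)nc3n2[C@H]2CCCNC2)COC1` differs from compound 3 by 3-methyloxetan-3-yl in place of methoxymethyl on a saturated chain carbon bound to a triple-bonded carbon. Within the data shown here, no measured step swaps an open ether for a ring at this place, so the measured step bears on it only loosely, and the spread of the repeats of compound 1 the several entries of compound 1 in this assay, 223 nM; 91 nM (2 entries) shows how much two readings of one compound can differ. The step is expected to stay near the scatter: a 1.5-fold higher number from compound 3 to compound 4 (0.19 log units; within the scatter). In this assay compound 4 is estimated at 60 nM, with a range from 20 nM to 180 nM.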

Compound 4, half-maximal effective concentration: 289 nM
Beside the measured number, compound 4's estimate is 4.8-fold (0.68 log units) below it; the whole stated range lies below it.
By their numbers in this assay, from the lowest: compound 3; then compounds 2 and 4 (each within the scatter of the next).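

In this assay, 3-methyloxetan-3-yl in place of methoxymethyl gives a 7.4-fold higher number from compound 3 to compound 4 (0.87 log units; beyond the scatter), so this place responds to the exchange even though the hydrogen-bond acceptor count stays the same. The other new step, a 2.0-fold higher number from compound 2 to compound 4 (0.29 log units; within the scatter), leaves the (3-methyloxetan-3-yl)methyl and 1-hydroxyethyl side chains unseparated. Single readings here need caution, as repeats of one compound can spread: the several entries of compound 1 in this assay, 223 nM; 91 nM (2 entries)

Going by these compounds, whether the change follows from the four-membered ring or from its added methyl and carbons remains open. Also open, on these data alone, is how a dimethylamino group or a longer open ether chain would read at this place.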